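The source may report more compounds than this note shows. Statements on the series, on what has been measured and on what is new or still open speak of the compounds shown alone.

In an ADME assay on HeLa cells (Homo sapiens) for cytotoxicity (a lower number here means that less compound is tolerated, a higher number that more compound is tolerated), compound 1 (`CC(=O)OC[C@H]1O[C@@H](n2cc(-c3cc(-c4ccccc4)no3)c(=O)[nH]c2=O)C[C@@H]1OC(C)=O`) gives 3000 nM. Compound 2 (`CC(C)(C)c1ccc(-c2cc(-c3cn([C@H]4C[C@H](O)[C@@H](CO)O4)c(=O)[nH]c3=O)on2)cc1`) gives 3000 nM, level with compound 1 at these digits. Compound 3 (`CC(=O)OC[C@H]1O[C@@H](n2cc(-c3cc(-c4ccc(C(C)C)cc4)no3)c(=O)[nH]c2=O)C[C@@H]1OC(C)=O`) departs from compound 1 in one place: isopropyl in place of hydrogen on an aromatic carbon, which is isopropyl in place of hydrogen on an aromatic carbon, so phenyl becomes 4-isopropylphenyl. Going by the values given here, no measured pair here differs in just one place, so the data give no direct guide to this change. No shift beyond the usual scatter is therefore expected in this assay, and the expected step is no change at the digits printed from compound 1 to compound 3 (within the scatter). Compound 3 is estimated at 3000 nM, within a range of 1200 nM to 7500 nM.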

Compound 3, half-maximal cytotoxic concentration: 3000 nM
Compound 3: the middle estimate sits on the measured number at the digits printed, within the range that was stated.
By their numbers in this assay, from the lowest: compounds 1, 2 and 3 (each within the scatter of the next).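

In this assay, going by these compounds alone, the swap of hydrogen for isopropyl on an aromatic carbon, which turns phenyl into 4-isopropylphenyl, gives no change at the digits printed from compound 1 to compound 3 (within the scatter) as the first direct reading of a single change at this position. At this place, para to a large group, three added carbons therefore leave the read-out within the usual scatter. No measurement here accounts for this result. On these data alone, whether an amine, a carboxylic acid or a longer chain at the same place would shift the number remains open.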